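Second methoxy on the aryl ketone of compound 2

This account rests on a few compounds, and the source may have more. Where it says the series, first, only, none or still open, it means among the compounds named here.

Measured compounds:
- compound 1 `COc1ccc(-c2cc3ccccc3nc2C=O)cc1`: in a functional assay on MDA-MB-231 cells (Homo sapiens) for antiproliferative activity, read by XTT assay, with a stated time of 72 h (a lower number here means a stronger inhibitor, a higher number a weaker inhibitor), compound 1 reaches only the assay limit > 10000 nM.
- compound 2 `COc1ccc(C(=O)/C=C/c2nc3ccccc3cc2-c2ccc(OC)cc2)cc1`: compound 2 gives 7540 nM.
- compound 3 `COc1ccc(-c2cc3ccccc3nc2/C=C/C(=O)c2c(OC)cccc2OC)cc1`: compound 3 gives 5630 nM.

Compound 2 holds the highest of the two numbers; compound 3 sits nearest, and the step of a 1.3-fold lower number from compound 2 to compound 3 (0.13 log units; within the scatter) is within the scatter. The value of compound 1 is a limit only (the limit of > 10000 nM in this assay, at which 1 of the 3 values shown sits).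

Compound 4 `COc1ccc(-c2cc3ccccc3nc2/C=C/C(=O)c2ccc(OC)c(OC)c2)cc1` differs from compound 2 by methoxy in place of hydrogen on an aromatic carbon. Within the data shown here, the only measured step that bears on it, a 1.3-fold lower number from compound 2 to compound 3 (0.13 log units; within the scatter), also added a methoxy to this aryl ketone and moved nothing beyond the scatter. The expected step of a 1.3-fold lower number from compound 2 to compound 4 (0.10 log units; within the scatter) is therefore small. Compound 4 is estimated at 6000 nM, between 2500 nM and 15000 nM.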

Compound 4, half-maximal inhibitory concentration: 4790 nM
Estimate against measurement, compound 4: 1.3-fold (0.10 log units) above, and the stated range covers the measured number.
By their numbers in this assay, from the lowest: compounds 4, 3 and 2 (each within the scatter of the next). At a limit, above all of these: compound 1.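

In this assay, going from 4-methoxyphenyl to 3,4-dimethoxyphenyl on the carbonyl carbon gives a 1.6-fold lower number from compound 2 to compound 4 (0.20 log units; within the scatter), so a methoxy ortho to a methoxy group brings no readable change at this ring. The two dimethoxyphenyl patterns do not separate either, with a 1.2-fold lower number from compound 3 to compound 4 (0.07 log units; within the scatter). Nothing measured here bears on this result.

Still open, going by these compounds, is whether any replacement on this aryl ketone moves the number beyond the scatter. A group other than methoxy at this position, such as an amine or a carboxylic acid, remains to be seen.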